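The source may report more compounds than this note shows. Statements on the series, on what has been measured and on what is new or still open speak of the compounds shown alone.

For the measured compounds named here, compound 2 `O=C(NCc1ccccc1)c1cccnc1Oc1ccccc1` gives 0.32 mg/kg in a functional assay on the whole organism with Mus musculus as the target (a lower number here means that less compound is needed, a higher number that more compound is needed for the effect), the highest of the two numbers measured so far; compound 1 `COC(=O)c1cccc(Oc2ncccc2C(=O)NCc2ccccc2)c1` gives 0.001 mg/kg, and a 320-fold higher number from compound 1 to compound 2 (2.51 log units; beyond the scatter). Compound 3 `O=C(NCc1ccccc1)c1cccnc1OC1CC2CCC1C2` differs from compound 2 in another place: a group of 7 heavy atoms (7 carbon; 2 five-membered non-aromatic rings of carbon only) in place of a group of 6 heavy atoms (6 carbon; one six-membered aromatic ring of carbon only), on an oxygen on an aromatic ring. Going by the values given here, the one measured step changes a methoxycarbonyl on an aromatic carbon, not the group on the oxygen on an aromatic ring, so it does not bear on this change, and no measured step points to a direction. The step is therefore expected to be no change at the digits printed from compound 2 to compound 3 (within the scatter), within the scatter. For compound 3 the expected value in this assay is 0.32 mg/kg, between 0.03 mg/kg and 3 mg/kg.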

Compound 3, minimum effective dose: 1 mg/kg
The estimate for compound 3 lay 3.1-fold (0.49 log units) below the measured number; measured number inside the range.
By their numbers in this assay, from the lowest: compound 1; then compound 2; then compound 3.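

Replacing the phenyl on the oxygen with the group of 2 five-membered non-aromatic rings gives a 3.1-fold higher number from compound 2 to compound 3 (0.49 log units; beyond the scatter) in this assay. An aromatic ring at this place is therefore not essential: compound 3 still has a measurable minimum effective dose, though more compound is needed. No measurement available here explains this difference. On these data alone, it remains open how an amine or a longer carbon chain on this oxygen would compare, and whether adding the methoxycarbonyl of compound 1 to compound 3 would lower the dose needed.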